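Replacing phenylcarbamoyl with 2-(methylcarbamoyl)ethenyl on the shared core

The source may report more compounds than this note shows. Statements on the series, on what has been measured and on what is new or still open speak of the compounds shown alone.

Three compounds share one core and differ only in the group on one aromatic carbon. In an in vitro assay on Sf9 cells for inhibition of 17-beta-hydroxysteroid dehydrogenase type 1 (Homo sapiens), tested at 100 nM (on this read-out lower numbers stand for a weaker effect and higher numbers for a stronger effect at the one concentration tested), compound 1 `O=C(c1c(O)ccc2cc(-c3cccc(O)c3)ccc12)N1CCOCC1` gives 28%, compound 2 `CNC(=O)c1c(O)ccc2cc(-c3cccc(O)c3)ccc12` gives 22%, and compound 3 `O=C(Nc1ccccc1)c1c(O)ccc2cc(-c3cccc(O)c3)ccc12` gives 40%. Compound 3 stands highest of the three: the step of a number 12 percentage points higher from compound 1 to compound 3 (beyond the scatter) and the step of a number 18 percentage points higher from compound 2 to compound 3 (beyond the scatter) both lie beyond the scatter, whereas the step of a number 6 percentage points lower from compound 1 to compound 2 (within the scatter) does not. Compound 4 `CNC(=O)/C=C/c1c(O)ccc2cc(-c3cccc(O)c3)ccc12` has not yet been measured. It differs from compound 3 in one place: 2-(methylcarbamoyl)ethenyl in place of phenylcarbamoyl on an aromatic carbon. The measured step most relevant to this change is a number 18 percentage points higher from compound 2 to compound 3 (beyond the scatter), in which phenyl replaced methyl on an amide-type nitrogen; compound 4 returns to a methyl on its amide-type nitrogen, though reached through the ethenyl. For the measured compounds named here, the step of a number 12 percentage points higher from compound 1 to compound 3 (beyond the scatter) points the same way, as the phenylcarbamoyl was the only group among the three that stood above the others, and compound 4 loses it. Going by the values given here, a modest decrease is therefore expected, back toward the number of compound 2, with the ethenyl having no precedent among the measured compounds. Compound 4 is estimated at 25%, between 10% and 40%. This amounts to an expected step of a number 15 percentage points lower from compound 3 to compound 4 (beyond the scatter).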

Compound 4, a percentage reported as inhibition, at one concentration (the size of the read-out at that concentration, not a potency): 19%
Compound 4: middle estimate off by 6 percentage points, on the high side; low and high end bracket the measured number.
By their numbers in this assay, from the lowest: compounds 4, 2 and 1 (each within the scatter of the next); then compound 3.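

In this assay, placing 2-(methylcarbamoyl)ethenyl on this aromatic carbon gives a number 3 percentage points lower from compound 2 to compound 4 (within the scatter) when it replaces methylcarbamoyl and a number 9 percentage points lower from compound 1 to compound 4 (within the scatter) when it replaces (morpholin-4-yl)carbonyl, so the added ethenyl sets compound 4 apart from neither of these amides. Only the change away from phenylcarbamoyl registers, as a number 21 percentage points lower from compound 3 to compound 4 (beyond the scatter), which leaves compound 3 alone beyond the scatter of the other three compounds at this position. Nothing available here accounts for this difference.

Going by these compounds, it remains open whether an ethenyl carrying phenylcarbamoyl would hold the level of compound 3 at 40% or fall back with the methyl amides. On these data alone, how a carboxylic acid or a saturated ethyl link in place of the ethenyl would read at this aromatic carbon also remains open.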